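The source may report more compounds than this note shows. Statements on the series, on what has been measured and on what is new or still open speak of the compounds shown alone.

Measured in a functional assay on HCT-116 cells (Homo sapiens) for inhibition, read by MTT assay, with a stated time of 48 h; on this read-out lower numbers stand for stronger inhibition and higher numbers for weaker inhibition:
- compound 1 `COc1ccc(CSc2nnc(-c3cc(OC)c(OC)c(OC)c3)n2-c2ccc(N(C)C)cc2)cc1`: 1150 nM
- compound 2 `COc1ccc(C(=O)CSc2nnc(-c3cc(OC)c(OC)c(OC)c3)n2-c2ccc(N(C)C)cc2)cc1O`: > 100000 nM, a limit of the assay

Compound 2 has no number and stands at the limit of > 100000 nM in this assay, at which 1 of the 2 values shown sits. Compound 3 `COc1cc(-c2nnc(SCC(=O)Nc3ccc(Cl)cc3)n2-c2ccc(N(C)C)cc2)cc(OC)c1OC` carries (4-chlorophenyl)amino in place of 3-hydroxy-4-methoxyphenyl on a carbonyl carbon. For the measured compounds named here, only one measured step bears on this, and only indirectly: the large at least 86-fold higher number from compound 1 to compound 2 (1.93 log units; beyond the scatter), which brought in that carbonyl. Going by the values given here, no measured compound carries the (4-chlorophenyl)amino group. Compound 3 keeps the carbonyl, so it is expected to stay weak, though with a moderate move to a lower number in this assay. The expected step is an at least 8.3-fold lower number from compound 2 to compound 3 (0.92 log units; beyond the scatter). In this assay, compound 3 is estimated at 12000 nM, with an expected range of 2500 nM to 60000 nM.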

Compound 3, half-maximal inhibitory concentration: 39300 nM
Compound 3: middle estimate off by 3.3-fold (0.52 log units), on the low side; measured number inside the range.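

In this assay, (4-chlorophenyl)amino in place of 3-hydroxy-4-methoxyphenyl on a carbonyl carbon gives an at least 2.5-fold lower number from compound 2 to compound 3 (0.40 log units; beyond the scatter), so a carbonyl at this position does not by itself hold the read-out at the limit. Compound 2 has only a limit of the assay: the limit of > 100000 nM in this assay, at which 1 of the 3 values shown sits. Even so, (4-chlorophenyl)carbamoyl in place of 4-methoxyphenyl gives a 34-fold higher number from compound 1 to compound 3 (1.53 log units; beyond the scatter), so the carbonyl-bearing compound 3 remains far weaker than compound 1.

Going by these compounds, what stays open is whether the amino nitrogen or the chlorine accounts for the change. A phenylamino or (4-methoxyphenyl)amino group on the same carbonyl carbon could separate the two.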